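Sulfonyl quinoline series: chloro to methoxy on the pendant aryl

This account rests on a few compounds, and the source may have more. Where it says the series, first, only, none or still open, it means among the compounds named here.

Measured so far in an ADME assay on microsomes from liver (Homo sapiens) for metabolic stability, tested at 2.5 uM; on this read-out lower numbers stand for slow clearance and higher numbers for fast clearance:
compound 1 `COc1cccc(-c2c(S(=O)(=O)c3ccc(OC)c(Cl)c3)cnc3cc(F)ccc23)c1` gives 1.71 mL/min
compound 2 `COc1cccc(-c2c(S(=O)(=O)c3cc(F)cc(F)c3)cnc3cc(F)ccc23)c1` gives 1.81 mL/min
compound 3 `N#Cc1cccc(S(=O)(=O)c2cnc3cc(F)ccc3c2-c2cccc(Cl)c2)c1` gives 0.99 mL/min

Compounds 1 and 2 share the 3-methoxyphenyl on the core and differ only on the sulfonyl sulfur; a 1.1-fold higher number from compound 1 to compound 2 (0.02 log units; within the scatter) in this assay. Compound 3 carries 3-chlorophenyl on the core together with a nitrile-bearing sulfonyl aryl, and of the three numbers its number is the lowest, though the gap to compound 1 and the gap to compound 2 are each within the scatter.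

Compound 4 `COc1cccc(-c2c(S(=O)(=O)c3cccc(C#N)c3)cnc3cc(F)ccc23)c1` is not yet measured. It differs from compound 3 by methoxy in place of chloro on an aromatic carbon. Going by the values given here, no measured step in this assay changes that group on that ring, so the only guide is that compound 4 shares the 3-methoxyphenyl of compound 1 and compound 2, whose numbers both stand somewhat above that of compound 3, and the nitrile-bearing sulfonyl aryl of compound 3. The step of a 1.5-fold higher number from compound 3 to compound 4 (0.18 log units; within the scatter) is therefore expected to be small and, if anything, toward a higher number, but not beyond the scatter. In this assay compound 4 is estimated at 1.5 mL/min, with a range from 0.9 mL/min to 2.5 mL/min.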

Compound 4, intrinsic clearance in a liver preparation (reported as CLH), per the amount of preparation that the assay uses: 1.83 mL/min
The estimate for compound 4 lay 1.2-fold (0.09 log units) below the measured number, within the range that was stated.
By their numbers in this assay, from the lowest: compounds 3, 1, 2 and 4 (each within the scatter of the next).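

In this assay, going by these compounds alone, 3-chlorophenyl to 3-methoxyphenyl with the 3-cyanophenyl on the sulfonyl sulfur held fixed gives the first readable step at this aromatic carbon, meta to a large group: a 1.8-fold higher number from compound 3 to compound 4 (0.27 log units; within the scatter) so this change does not separate from the scatter. With 3-methoxyphenyl held fixed, the sulfonyl aryl now has three members, and the steps of a 1.0-fold higher number from compound 2 to compound 4 (0.00 log units; within the scatter) and a 1.1-fold higher number from compound 1 to compound 4 (0.03 log units; within the scatter) leave 3-cyanophenyl, 3,5-difluorophenyl and 3-chloro-4-methoxyphenyl on the sulfonyl sulfur not told apart in this read-out. No measurement at hand gives a reason for these results.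

From the compounds shown here alone, whether a group other than chloro or methoxy at this place, such as an amine or a carboxylic acid, would move the number beyond the scatter remains open. Also open is whether the two sites act independently, since among the compounds shown 3-chlorophenyl occurs only with 3-cyanophenyl on the sulfonyl sulfur.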